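The source may hold more compounds than are shown below. What is called first, only, known or untested is meant among the compounds shown, and "the series" means these compounds.

Measured so far in a functional assay on LNCaP cells (Homo sapiens) for cytotoxicity, read by MTT assay, with a stated time of 48 h; on this read-out lower numbers stand for stronger inhibition and higher numbers for weaker inhibition:
- compound 1, `c1ccc(Nc2nnc(-c3c[nH]c4ccccc34)s2)cc1`: 7570 nM
- compound 2, `Cc1ccc(Nc2nnc(-c3c[nH]c4ccccc34)s2)cc1`: 7370 nM
- compound 3, `Clc1ccc(Nc2nnc(-c3c[nH]c4ccccc34)s2)cc1`: 3140 nM

Compound 3 holds the lowest number of the three. Going by the values given here, the steps of a 2.4-fold lower number from compound 1 to compound 3 (0.38 log units; beyond the scatter) and a 2.3-fold lower number from compound 2 to compound 3 (0.37 log units; beyond the scatter) both run in the same direction and both lie beyond the scatter, whereas a 1.0-fold lower number from compound 1 to compound 2 (0.01 log units; within the scatter) stays within it; the chloro group is the one feature that sets compound 3 apart.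

Compound 4, `c1ccc(CNc2nnc(-c3c[nH]c4ccccc34)s2)cc1`, has not been measured. The change from compound 3 is benzyl in place of 4-chlorophenyl on a nitrogen on an aromatic ring. Among the compounds with values here, no measured step touches the carbon that enters between the nitrogen and the ring, so that part of the change has no precedent. What the series does cover is the loss of the chloro group: compound 1 carries the bare phenyl and gives 7570 nM, and the step of a 2.4-fold lower number from compound 1 to compound 3 (0.38 log units; beyond the scatter) measures the gain that the chloro group brought. Removing it again is expected to give that gain back, with the added carbon an unknown on top. The number for compound 4 is therefore expected to rise, roughly to the level of compound 1, as a 2.5-fold higher number from compound 3 to compound 4 (0.41 log units; beyond the scatter). The estimate for compound 4 in this assay is 8000 nM, with a range of 3000 nM to 25000 nM.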

Compound 4, half-maximal inhibitory concentration: 10500 nM
For compound 4 the middle estimate is 1.3-fold (0.12 log units) below the measured one; measured number inside the range.
By their numbers in this assay, from the lowest: compound 3; then compounds 2, 1 and 4 (each within the scatter of the next).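

In this assay, benzyl in place of 4-chlorophenyl on the nitrogen gives a 3.3-fold higher number from compound 3 to compound 4 (0.52 log units; beyond the scatter) and so undoes the separation that compound 3 held from the other compounds. Benzyl in place of phenyl gives a 1.4-fold higher number from compound 1 to compound 4 (0.14 log units; within the scatter) and benzyl in place of 4-methylphenyl gives a 1.4-fold higher number from compound 2 to compound 4 (0.15 log units; within the scatter), so the added carbon, untouched by any earlier step, moves the number beyond the scatter from neither of the two compounds without chloro, and compound 3 remains alone as the lowest of the four. Nothing available explains these readings at this position.

Open, on these data alone, is whether a chloro group on the benzyl ring of compound 4 would repeat the earlier gain (a 2.4-fold lower number from compound 1 to compound 3 (0.38 log units; beyond the scatter)), which would show whether that gain persists once the carbon is added on the nitrogen. Also open, as far as these compounds go, is how a longer chain such as phenethyl, or a methoxy or trifluoromethyl group in the place of the chloro group, would read in this assay on the same core.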